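Trading a Ring for an Open Chain in Compound 4

The source may hold more compounds than are shown below. What is called first, only, known or untested is meant among the compounds shown, and "the series" means these compounds.

Of the compounds shown here, three have been measured in a functional assay on Umbilical vein for antagonist activity at B1 bradykinin receptor (Homo sapiens), using Schild analysis, with a stated time of 30 min; a higher number here means a more potent compound, by a factor of ten per unit of this negative logarithm, a lower number a less potent compound. Compound 1 `CCN(CC)CCN1CCN(C(=O)COCCN(C)S(=O)(=O)c2c(C)cc(OC)cc2C)CC1` gives 7.8. Compound 2 `Cc1c(Cl)ccc(S(=O)(=O)N(C)CCOCC(=O)N(C)Cc2ccc(C3=NCCN3)cc2)c1Cl` gives 9.1, and compound 3 `COc1cc(C)c(S(=O)(=O)N(C)CCOCC(=O)N2CCC(C3CCN(C)CC3)CC2)c(C)c1` gives 9. Compound 3 thus stands second of the three numbers: its value and that of compound 2 lie within the scatter of each other, whereas the value of compound 1 lies beyond the scatter below it.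

Compound 4 `COc1cc(C)c(S(=O)(=O)N(C)CCOCC(=O)N2CCC(C(O)CN(C)C)CC2)c(C)c1` differs from compound 3 in one place: 2-(dimethylamino)-1-hydroxyethyl in place of 1-methylpiperidin-4-yl on a saturated ring carbon. Going by the values given here, no measured pair shows the effect of this kind of change, so no step can be drawn from the data. Compound 3 and compound 2, built around different central parts, both reach about the same level in this assay, while compound 1 shows that other arrangements of the ends fall off by more than the scatter. For compound 4 a modest loss is expected, a number 0.40 log units lower from compound 3 to compound 4 (beyond the scatter), though a change no larger than the scatter would not surprise. The estimate for compound 4 in this assay is 8.6, with a range from 7.9 to 9.3.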

Compound 4, negative logarithm of the antagonist equilibrium constant: 7.4
Compound 4: middle estimate off by 1.20 log units, on the high side; the whole stated range lies above it.
By their numbers in this assay, from the lowest: compound 4; then compound 1; then compounds 3 and 2 (each within the scatter of the next).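

In this assay, putting 2-(dimethylamino)-1-hydroxyethyl in place of 1-methylpiperidin-4-yl on the saturated ring carbon gives a number 1.60 log units lower from compound 3 to compound 4 (beyond the scatter) and is a large step, the first one seen at this position. The position therefore does not accept every group that carries an amine nitrogen, even though the entering group has 6 heavy atoms against the 7 of the group that leaves, and it does not hold the level of compound 3 once the ring gives way to an open chain bearing a hydrogen-bond donor. Nothing measured here explains the loss.

The compounds shown leave open how much of the step belongs to the lost ring and how much to the added hydroxyl. A plain 2-(dimethylamino)ethyl chain, or a 1-methylpiperidin-4-yl ring joined through a hydroxyl-bearing carbon, would separate the two.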